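Naphthyloxyacetyl hydrazones: tolerance of HEL cells to compound 4

The source may hold more compounds than are shown below. What is called first, only, known or untested is meant among the compounds shown, and "the series" means these compounds.

The measured compounds and their values:
compound 1, `O=C(COc1cccc2ccccc12)N/N=C/C=C/c1ccccc1`, 100 ug/mL
compound 2, `O=C(COc1cccc2ccccc12)N/N=C/c1ccc([N+](=O)[O-])cc1`, 14.2 ug/mL
compound 3, `O=C(COc1cccc2ccccc12)N/N=C/c1ccccc1Cl`, 62.7 ug/mL

All three share a common core and differ only in the group on the carbon that carries the double bond to nitrogen. In an ADME assay on HEL cells (Homo sapiens) for cytotoxicity (a lower number here means that less compound is tolerated, a higher number that more compound is tolerated), compound 3 gives 62.7 ug/mL, the second highest of the three numbers. Its nearest neighbour is compound 1, which gives 100 ug/mL; the two lie within the scatter of each other. Compound 2 gives 14.2 ug/mL, and the gap between compound 2 and compound 3 is beyond the scatter, so less of compound 2 is tolerated.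

Compound 4, `Cc1ccc(/C=N/NC(=O)COc2cccc3ccccc23)cc1`, has not yet been measured. It differs from compound 3 in one place: 4-methylphenyl in place of 2-chlorophenyl on a carbon with a double bond to nitrogen.

Going by the values given here, only one measured step changes this same group, a 1.6-fold lower number from compound 1 to compound 3 (0.20 log units; within the scatter). That step, though it exchanges a whole group, stays within the scatter. Among the compounds with values here, the pair of compound 2 and compound 3 shows that a different substituent on the same ring can move the number beyond the scatter, yet no step is given for that pair. With a methyl in place of a chlorine on an otherwise comparable ring, compound 4 is expected to change little from compound 3, and the expected step is a 1.1-fold higher number from compound 3 to compound 4 (0.05 log units; within the scatter). The estimate for compound 4 in this assay is therefore 70 ug/mL, with a range from 35 ug/mL to 140 ug/mL.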

Compound 4, half-maximal cytotoxic concentration: 80.1 ug/mL
Estimate against measurement, compound 4: 1.1-fold (0.06 log units) below; low and high end bracket the measured number.
By their numbers in this assay, from the lowest: compound 2; then compounds 3, 4 and 1 (each within the scatter of the next).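

In this assay, a 1.3-fold higher number from compound 3 to compound 4 (0.11 log units; within the scatter) and a 1.2-fold lower number from compound 1 to compound 4 (0.10 log units; within the scatter), so 4-methylphenyl joins 2-chlorophenyl and 2-phenylethenyl as a third group on the carbon with a double bond to nitrogen, and all three lie within the scatter of one another. The step that goes beyond the scatter is a 5.6-fold higher number from compound 2 to compound 4 (0.75 log units; beyond the scatter), with methyl in place of nitro on an aromatic carbon; this is the first listed step to show that a single change on the ring can move the number that far, while the whole-group exchanges among compounds 1, 3 and 4 do not. Nothing measured here accounts for the gap between the nitro and the methyl compound.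

The exchange from compound 3 to compound 4 alters both the atom on the ring and the name of the ring position, so it cannot show what either change does alone, and 4-chlorophenyl or 2-methylphenyl would separate the two. On these data alone, it also remains open whether an amine, a carboxylic acid or a longer chain in place of the methyl of compound 4 would stay with compounds 1, 3 and 4 or come closer to compound 2 at 14.2 ug/mL.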